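Swapping chloro for fluoro on a benzyl sulfide

The source may report more compounds than this note shows. Statements on the series, on what has been measured and on what is new or still open speak of the compounds shown alone.

Of the compounds shown here, three that share a core have been tested in a functional assay on the whole organism (artery, strain albino) with Rattus norvegicus as the target, with a stated time of 180 min, at a dose of 10 mg/kg by the oral route; a higher number here means more inhibition at the dose given (going by the name of the read-out), a lower number less inhibition. Compound 1, `CC1=C(C(=O)Nc2ccc(Br)cc2)C(c2ccc(Cl)cc2Cl)N=C(SCc2ccc(Cl)cc2)N1`, gives 23.2%. Compound 2, `CC1=C(C(=O)Nc2ccc(Br)cc2)C(c2ccc(Cl)cc2Cl)N=C(SCc2ccc(F)cc2)N1`, gives 28.4%. Compound 2 differs from compound 1 by fluoro in place of chloro on an aromatic carbon. The measured step is a number 5.2 percentage points higher from compound 1 to compound 2 (within the scatter). Compound 3, `COc1ccc(C2N=C(SCc3ccc(Cl)cc3)NC(C)=C2C(=O)Nc2ccc(Br)cc2)cc1`, gives 22.7%. Compound 3 differs from compound 1 in its core by 4-methoxyphenyl in place of 2,4-dichlorophenyl on a saturated ring carbon. That step reads a number 0.5 percentage points lower from compound 1 to compound 3 (within the scatter). Among the three measured compounds, the numbers all sit close together.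

Compound 4, `COc1ccc(C2N=C(SCc3ccc(F)cc3)NC(C)=C2C(=O)Nc2ccc(Br)cc2)cc1`, has not yet been measured. It differs from compound 3 by fluoro in place of chloro on an aromatic carbon. This is the same change, at the same place, that turns compound 1 into compound 2; among the four compounds it occurs two times in all. The two pairs are built on cores that differ as described by the change from compound 1 to compound 3.

For compound 4 in this assay the expected step is a number 4.3 percentage points higher from compound 3 to compound 4 (within the scatter), set beside the measured step of a number 5.2 percentage points higher from compound 1 to compound 2 (within the scatter), and it rests on the fact that the same change in the other pair gave a step within the scatter. Compound 4 is therefore estimated to give 27%. The likely range for compound 4 is expected to run from 15% to 39%.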

Compound 4, a percentage reported as inhibition, in the whole organism at one dose (the size of the read-out at that dose, not a potency): 17%
Compound 4: middle estimate off by 10 percentage points, on the high side; the range from low to high includes it.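

On fluoro in place of chloro, this assay gives a step that reads a number 5.7 percentage points lower from compound 3 to compound 4 (within the scatter), and set beside the same change on the core of compound 1, the two steps cannot be told apart: the same change on two cores in this assay, a number 5.2 percentage points higher (within the scatter) from compound 1 to compound 2 and a number 5.7 percentage points lower (within the scatter) from compound 3 to compound 4, 10.9 percentage points apart, within the scatter of two such steps. Among the compounds shown here, the change from 2,4-dichlorophenyl to 4-methoxyphenyl reads a number 11.4 percentage points lower from compound 2 to compound 4 (beyond the scatter), the one new step that clears the scatter, yet it too cannot be told apart from its counterpart in the chloro pair: the same change on two cores in this assay, a number 0.5 percentage points lower (within the scatter) from compound 1 to compound 3 and a number 11.4 percentage points lower (beyond the scatter) from compound 2 to compound 4, 10.9 percentage points apart, within the scatter of two such steps. So nothing here shows that the core alters what either change does, but nothing shows that the fluoro change does anything measurable on either core, and a match between steps this small is weak support for carrying a change from one core to another, as each step rests on one reading at one dose.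

The compounds shown leave open whether a different group on the benzyl ring, such as an amine or a carboxylic acid in place of chloro or fluoro, would give a step beyond the scatter on both cores. They also leave open what a longer chain in place of the 4-fluorobenzyl group would do.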